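Shortening the hydroxamate linker on the shared core

This account rests on a few compounds, and the source may have more. Where it says the series, first, only, none or still open, it means among the compounds named here.

Compound 1 `Nc1ncnc2c1c(-c1cnc3[nH]ccc3c1)nn2CCCC(=O)NO` and compound 2 `Nc1ncnc2c1c(-c1cnc3[nH]ccc3c1)nn2CCCCCCCCCC(=O)NO` share one core and differ in chain length. Within the data shown here, in a functional assay on HeLa cells (Homo sapiens) for inhibition, read by MTT assay, with a stated time of 72 h (on this read-out higher numbers stand for weaker inhibition and lower numbers for stronger inhibition), compound 2 gives 7560 nM, the only number available; in this assay compound 1 gives "not determined" (no result reported), so no result stands for it. Compound 3 `Nc1ncnc2c1c(-c1cnc3[nH]ccc3c1)nn2CCCCCC(=O)NO` carries the change (hydroxycarbamoyl in place of 4-(hydroxycarbamoyl)butyl on a saturated chain carbon, five bonds along the chain from an aromatic nitrogen). Among the measured compounds shown here, no step between measured compounds exists to calibrate this change, so the expected step of a 1.6-fold higher number from compound 2 to compound 3 (0.20 log units; within the scatter) is set as a modest loss, not clearly beyond the usual scatter. Compound 3 is therefore estimated at 12000 nM, with a range from 3000 nM to 45000 nM.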

Compound 3, half-maximal inhibitory concentration: > 150000 nM
Compound 3: no number, only a limit (the forecaster's own chance of this, stated with the estimate: 20%); at least 12-fold (1.09 log units) between middle value and limit.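

Removing the four-carbon stretch between the two chain lengths is not a neutral change at this position, on a saturated chain carbon, five bonds along the chain from an aromatic nitrogen: this assay gives an at least 19-fold higher number from compound 2 to compound 3 (1.29 log units; beyond the scatter). The reading for compound 3 is a limit and not a number: the limit of > 150000 nM in this assay, at which 1 of the 3 values shown sits. The step therefore fixes a minimum size for the loss, not its true size.

Steps involving compound 1 cannot be read, so the effect of a still shorter chain stays unresolved. Open too, going by these compounds, are a chain longer than that of compound 2 and a carboxylic acid in place of the hydroxycarbamoyl end.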